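Aryl swap on the three-membered ring of compound 2

The source may report more compounds than this note shows. Statements on the series, on what has been measured and on what is new or still open speak of the compounds shown alone.

Going by the values given here, compound 2 `CC[C@H](C)[C@H](N)CN(C(=O)[C@@H]1C[C@H]1c1cncnc1)c1ccc(-c2ccccc2)cc1` holds the only number: in a functional assay for agonist activity at G protein-coupled receptor 88 (Homo sapiens), read by HTRF and cAMP accumulation (on this read-out lower numbers stand for an effect already at smaller amounts and higher numbers for an effect only at larger amounts of compound), compound 2 gives 19000 nM. Compound 1 `CC[C@H](C)[C@H](N)CN(C(=O)[C@@H]1C[C@H]1c1ccc(C#N)cc1)c1ccc(-c2ccccc2)cc1` is known only as a limit of the assay; in this assay compound 1 gives > 25000 nM (the limit of > 25000 nM in this assay, at which 1 of the 2 values shown sits). Among the compounds with values here, the single measured step, an at least 1.3-fold lower number from compound 1 to compound 2 (0.11 log units; that floor lies within the scatter), exchanges the aryl on the same saturated ring carbon and barely moves the read-out. Compound 3 `CC[C@H](C)[C@H](N)CN(C(=O)[C@@H]1C[C@H]1c1ccoc1)c1ccc(-c2ccccc2)cc1` carries furan-3-yl in place of pyrimidin-5-yl on a saturated ring carbon. Within the data shown here, with an at least 1.3-fold lower number from compound 1 to compound 2 (0.11 log units; that floor lies within the scatter) as the only guide, no step beyond the scatter is expected for a 1.2-fold lower number from compound 2 to compound 3 (0.07 log units; within the scatter). Compound 3 is estimated at 16000 nM, within 5000 nM to 50000 nM.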

Compound 3, half-maximal effective concentration: 580 nM
Compound 3: the middle estimate sits 28-fold (1.44 log units) above what was measured; the measured number lies below the stated range.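

The aryl on the saturated ring carbon can move the read-out strongly, which the earlier step, within the scatter, did not show: furan-3-yl in place of pyrimidin-5-yl gives a 33-fold lower number from compound 2 to compound 3 (1.52 log units; beyond the scatter). Against 4-cyanophenyl, furan-3-yl gives an at least 43-fold lower number from compound 1 to compound 3 (1.63 log units; beyond the scatter). That step is only a floor, and the value for compound 1 is a limit, not a number: the limit of > 25000 nM in this assay, at which 1 of the 3 values shown sits.

As far as these compounds go, whether the gain is particular to furan-3-yl remains open, since the effect of furan-2-yl, thiophen-3-yl or plain phenyl at this position is unknown here.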